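Chloro for Nitro in a Two-Compound Series

The source may report more compounds than this note shows. Statements on the series, on what has been measured and on what is new or still open speak of the compounds shown alone.

Measured compounds:
compound 1, `COc1ccc(C(Nc2ccccc2)n2c(=O)ccc3cc(O)ccc32)cc1`, 79700 nM
compound 2, `COc1ccc(C(Nc2ccc([N+](=O)[O-])cc2)n2c(=O)ccc3cc(O)ccc32)cc1`, 48000 nM

In a functional assay on PC-3 cells (Homo sapiens) for inhibition, read by MTT assay (on this read-out higher numbers stand for weaker inhibition and lower numbers for stronger inhibition), compound 2 holds the lower of the two numbers, but the step of a 1.7-fold lower number from compound 1 to compound 2 (0.22 log units; within the scatter) is within the scatter, so neither compound can be called more active. Compound 3, `COc1ccc(C(Nc2ccc(Cl)cc2)n2c(=O)ccc3cc(O)ccc32)cc1`, differs from compound 2 by chloro in place of nitro on an aromatic carbon. Among the measured compounds shown here, the only measured step, the introduction of nitro from compound 1 to compound 2, touches the same position and was within the scatter; nothing measured speaks to chloro itself. Compound 3 is therefore expected to stay close to compound 2, a step of a 1.1-fold higher number from compound 2 to compound 3 (0.06 log units; within the scatter), with an estimate of 55000 nM and a range from 25000 nM to 120000 nM.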

Compound 3, half-maximal inhibitory concentration: 35200 nM
Beside the measured number, compound 3's estimate is 1.6-fold (0.19 log units) above it; measured number inside the range.
By their numbers in this assay, from the lowest: compounds 3, 2 and 1 (each within the scatter of the next, the first and the last beyond it).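

In this assay, among the compounds shown here, the step of a 2.3-fold lower number from compound 1 to compound 3 (0.35 log units; beyond the scatter) is the first at this position, para to a large group, to lie beyond the scatter, though it is modest. The step of a 1.4-fold lower number from compound 2 to compound 3 (0.13 log units; within the scatter) shows that chloro and nitro cannot be told apart here, so one heavy atom in place of three leaves the number within the scatter. Nothing available explains this result. The compounds shown leave open whether an amine or a carboxylic acid on this carbon would give a number close to those of compound 2 and compound 3.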